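Hydroxy for methyl on a sulfonamide ring

The source may hold more compounds than are shown below. What is called first, only, known or untested is meant among the compounds shown, and "the series" means these compounds.

Measured so far:
compound 1 `O=S(=O)(Nc1ccc(-c2nc3ccccc3o2)cc1)c1ccc(F)c(C(F)(F)F)c1`, in an ADME assay on HEK293 cells (Homo sapiens) for cytotoxicity, read by resazurin assay, with a stated time of 48 h (on this read-out lower numbers stand for higher toxicity in this test and higher numbers for lower toxicity in this test), compound 1 gives 82000 nM
compound 2 `Cc1cccc(S(=O)(=O)Nc2ccc3oc(-c4ccccc4)nc3c2)c1`, in this assay compound 2 gives 69000 nM
compound 3 `O=S(=O)(Nc1ccc(-c2nc3ccccc3o2)cc1)c1ccccc1Cl`, for which this assay reports a limit of > 100000 nM

All three compounds share a core carrying a sulfonamide. Of the two numbers in hand, compound 2 has the lower one, and compound 1 sits close enough to it that the two are within the usual scatter, so no order between them can be claimed. The value of compound 3 is a limit of the assay, not a number, as stated in the limit of > 100000 nM in this assay, at which 1 of the 3 values shown sits.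

Compound 4 `O=S(=O)(Nc1ccc2oc(-c3ccccc3)nc2c1)c1cccc(O)c1` has not been measured. It differs from compound 2 in one place: hydroxy in place of methyl on an aromatic carbon. Among the compounds with values here, no pair of measured compounds shows this change, so no measured step can be pointed to. The expectation is that the step from compound 2 to compound 4 in this assay stays within the scatter, with no direction beyond it, and that expected step is a 1.2-fold higher number from compound 2 to compound 4 (0.06 log units; within the scatter). Compound 4 is thus estimated at 80000 nM, with a range from 40000 nM to 160000 nM.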

Compound 4, half-maximal cytotoxic concentration: > 100000 nM
Compound 4 gave a limit, no number; the forecaster's own chance of this, stated with the estimate: 35%; middle value at least 1.2-fold (0.09 log units) from the limit.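

Hydroxy in place of methyl gives the first step in this assay between two compounds that differ in one place: an at least 1.4-fold higher number from compound 2 to compound 4 (0.16 log units; that floor lies within the scatter). This step is only a floor because the value of compound 4 is a limit, not a number: the limit of > 100000 nM in this assay, at which 2 of the 4 values shown sit. At this position, the change from 3-methylphenyl to 3-hydroxyphenyl therefore gives no sign of higher toxicity in this test, although the floor alone cannot establish a real change in either direction.

The compounds shown leave open how large the step from methyl to hydroxy really is, since the upper end of the step is not known. They also leave open what an amine or a carboxylic acid would give at this same position on the ring, and whether hydroxy for methyl would read the same way on another core.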